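The source may hold more compounds than are shown below. What is called first, only, known or untested is meant among the compounds shown, and "the series" means these compounds.

Measured compounds in an assay on CHO cells for displacement of a labelled ligand from adenosine receptor A3 (Homo sapiens), read by scintillation counting, with a stated time of 120 min, tested at 1 uM; on this read-out higher numbers stand for more inhibition at the one concentration tested (going by the name of the read-out) and lower numbers for less inhibition:
compound 1 `N#Cc1c(N)nc2sc(C(N)=O)c(N)c2c1-c1ccc(OCC2CC2)cc1`, 13%;
compound 2 `N#Cc1c(N)nc(SCc2nnn[nH]2)c(C#N)c1-c1ccc(OCC2CC2)cc1`, 1%;
compound 3 `CC(C)COc1ccc(-c2c(C#N)c(N)nc(SCC(N)=O)c2C#N)cc1`, 9%.

On these numbers compound 2 stands lowest. Compound 3 lies within the scatter of compound 2, so the two cannot be told apart, while compound 1 sits beyond the scatter above both. Compound 4 `N#Cc1c(N)nc(SCc2csc(N)n2)c(C#N)c1-c1ccc(OCC2CC2)cc1`, not yet measured, differs from compound 2 in one place: 2-amino-1,3-thiazol-4-yl in place of 1H-tetrazol-5-yl on a saturated chain carbon bound to a sulfur. Among the compounds with values here, no measured pair shows the effect of this exchange, so the expectation rests on the low numbers of compounds 2 and 3 alone. The step of a number 4 percentage points higher from compound 2 to compound 4 (within the scatter) is expected to be small and not beyond the scatter. Compound 4 is therefore estimated at 5% in this assay, with a range from 0% to 15%.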

Compound 4, a percentage reported as inhibition, at one concentration (the size of the read-out at that concentration, not a potency): 1%
The estimate for compound 4 lay 4 percentage points above the measured number, and the stated range covers the measured number.
By their numbers in this assay, from the lowest: compounds 2, 4, 3 and 1 (each within the scatter of the next, the first and the last beyond it).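

In this assay, 2-amino-1,3-thiazol-4-yl in place of 1H-tetrazol-5-yl on a saturated chain carbon bound to a sulfur gives no change at the digits printed from compound 2 to compound 4 (within the scatter). Within the data shown here, this is the first direct reading of a change at this position: a five-membered aromatic ring with 2 hetero atoms and one with 4 cannot be told apart here. No supporting data bear on this result.

From the compounds shown here alone, what a carboxylic acid, a phenyl ring or a longer chain would give on this sulfur stays open. Going by these compounds, since the read-out comes from one concentration, any difference in potency between compound 2 and compound 4 also stays open.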